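The compounds below may be only part of what the source reports. "The series", "measured", "known", "first", "only" and "open" are said of these compounds alone.

Working notes on the oxazolidinone amide series in an assay on HEK293 cells for inhibition of N-acylethanolamine-hydrolyzing acid amidase (Rattus norvegicus), read by LC-MS, with a stated time of 30 min; on this read-out lower numbers stand for stronger inhibition and higher numbers for weaker inhibition.

For the measured compounds named here, compound 1, `O=C(CCCCCc1ccc(Br)cc1)N1CCOC1=O`, is the only member so far with a number: in this assay compound 1 gives 8510 nM. For compound 2, `O=C(CCCCCc1ccc(I)cc1)N1CCOC1=O`, the read-out is a limit of the assay, > 20000 nM. For compound 3, `COc1ccc(CCCCCC(=O)N2CCOC2=O)cc1`, the read-out is likewise a limit, > 20000 nM. Going by the values given here, compound 3 therefore sits at the limit of > 20000 nM in this assay, at which 2 of the 3 values shown sit, and the step of an at least 2.3-fold higher number from compound 1 to compound 3 (0.37 log units; beyond the scatter) is the only one from a numbered value that reaches it; the pair of limits leaves a step that the two limits leave unreadable from compound 2 to compound 3 unreadable. Among the compounds with values here, the step of an at least 2.3-fold higher number from compound 1 to compound 2 (0.37 log units; beyond the scatter) is the only other measured step in the set.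

Compound 4, `O=C(CCCCCc1ccc(C(F)(F)F)cc1)N1CCOC1=O`, differs from compound 3 in one place: trifluoromethyl in place of methoxy on an aromatic carbon. Within the data shown here, no measured step exchanges methoxy for trifluoromethyl, so the direction from compound 3 is open. The two steps that bear on it, both leaving bromo, were an at least 2.3-fold higher number from compound 1 to compound 3 (0.37 log units; beyond the scatter) and an at least 2.3-fold higher number from compound 1 to compound 2 (0.37 log units; beyond the scatter), each at least modest and each without an upper bound. Weighing these, compound 4 is estimated at 12000 nM, with a range from 3000 nM to 40000 nM; this amounts to an expected at least 1.6-fold lower number from compound 3 to compound 4 (0.22 log units; that floor lies within the scatter), with a substantial chance that the assay again returns only a limit.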

Compound 4, half-maximal inhibitory concentration: 1040 nM
The estimate for compound 4 lay 12-fold (1.06 log units) above the measured number; the measured number lies below the stated range.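

For the compounds shown here, until now, every change away from bromo at this aromatic carbon, para to a large group, had only weakened inhibition in this assay; trifluoromethyl is the first group there to go the other way, and the step is an 8.2-fold lower number from compound 1 to compound 4 (0.91 log units; beyond the scatter). The same group also gives an at least 19-fold lower number from compound 3 to compound 4 (1.28 log units; beyond the scatter) and an at least 19-fold lower number from compound 2 to compound 4 (1.28 log units; beyond the scatter), so with the rest of the structure shared, the group at this one place separates a compound with a measured number from compounds that reach only the limit of the assay. Both of those larger steps start from a limit, which makes each a floor rather than a true size, and the step between compound 2 and compound 3 cannot be read: the limit of > 20000 nM in this assay, at which 2 of the 4 values shown sit.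

The compounds shown leave open whether a nitrile, an amine or a carboxylic acid at the same place would follow trifluoromethyl or fall back to the limit. They also leave open why trifluoromethyl stands apart from bromo, and whether a shorter or longer chain between the carbonyl and the aromatic ring would move the number of compound 4.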